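A Cyclic Replacement for the 3,4-Dimethoxyphenyl Group

A few compounds are considered here, and "the series" means these few. Any claim that something is new, unique, unknown or untested is made for them only; others in the source may bear on it.

Measured compounds:
compound 1 `COc1ccc(C(=O)NC(=S)Nc2cccc(-c3nc4ccccc4[nH]3)c2)cc1OC`: > 10000 nM
compound 2 `COc1ccc(C(=O)NC(=O)Nc2cccc(-c3nc4ccccc4[nH]3)c2)cc1OC`: "not determined" (no result reported)
compound 3 `CCOc1ccc(C(=O)NC(=S)Nc2cc(-c3nc4ccccc4[nH]3)ccc2C)cc1OCC`: "not determined" (no result reported)

In a functional assay on MDA-MB-231 cells (Homo sapiens) for cytotoxicity, read by WST assay, with a stated time of 48 h (on this read-out lower numbers stand for stronger inhibition and higher numbers for weaker inhibition), compound 1 reaches only a limit, > 10000 nM, which is not a measured number. For compound 2 the same this assay reports "not determined" (no result reported), and for compound 3 it reports "not determined" (no result reported). Compound 1 therefore carries the only reported entry, and that entry is a limit (the limit of > 10000 nM in this assay, at which 1 of the 3 values shown sits). Among the measured compounds shown here, no step between two measured compounds exists here. Compound 4 `O=C(NC(=S)Nc1cccc(-c2nc3ccccc3[nH]2)c1)c1ccc2c(c1)OCCO2` differs from compound 1 in one place.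

2,3-dihydro-1,4-benzodioxin-6-yl in place of 3,4-dimethoxyphenyl on a carbonyl carbon

For the measured compounds named here, with no measured step to lean on, the expected step that the limit leaves unreadable from compound 1 to compound 4 is estimated to stay within the scatter of repeated measurements. Compound 4 is expected to give about 12000 nM, within 4000 nM to 40000 nM, most probably reported again only as a limit.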

Compound 4, half-maximal inhibitory concentration: 400 nM
For compound 4 the middle estimate is 30-fold (1.48 log units) above the measured one; the measured number lies below the stated range.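

Replacing 3,4-dimethoxyphenyl with 2,3-dihydro-1,4-benzodioxin-6-yl on a carbonyl carbon gives an at least 25-fold lower number from compound 1 to compound 4 (1.39 log units; beyond the scatter) in this assay. The two groups hold the same count of heavy atoms and the same carbon and oxygen atoms, so this position responds strongly to joining the two oxygens in a ring. Compound 1 has only a limit, not a measured number, so the true step size stays unknown: the limit of > 10000 nM in this assay, at which 1 of the 4 values shown sits.

The compounds shown leave open why the ring matters and whether its size does. A 1,3-benzodioxol-5-yl group on the same carbonyl carbon would bear on the second question.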